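The source may report more compounds than this note shows. Statements on the series, on what has been measured and on what is new or still open speak of the compounds shown alone.

Working notes on the series. Compound 1 `O=C(Nc1cccc(-n2cc(-c3ccncc3)c(-c3cc(O)cc(Cl)c3)n2)c1)Nc1ccc(Cl)c(Cl)c1` and compound 2 `COc1cc(Cl)cc(-c2nn(-c3cccc(NC(=O)Nc4ccc(Cl)c(Cl)c4)c3)cc2-c2ccncc2)c1` share one core and differ only by methyl in place of hydrogen on an oxygen on an aromatic ring. In a functional assay on NCI-H226 cells (Homo sapiens) for inhibition, read by sulforhodamine B assay, with a stated time of 48 h, tested at 10 uM (a higher number here means a weaker effect of the compound at the concentration tested, a lower number a stronger effect), compound 1 gives 14.5%, and in this assay compound 2 gives 7.27%. The step of a number 7.2 percentage points lower from compound 1 to compound 2 (within the scatter) is within the scatter, so the two numbers cannot be told apart and compound 2 stands alongside compound 1 rather than apart from it; nothing in these two numbers ranks either one.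

Compound 3 `COc1cc(Cl)cc(-c2nn(-c3cccc(NC(=O)c4cccc(C(F)(F)F)c4)c3)cc2-c2ccncc2)c1` is not yet measured. It differs from compound 2 by 3-(trifluoromethyl)phenyl in place of (3,4-dichlorophenyl)amino on a carbonyl carbon. Within the data shown here, the only measured step, a number 7.2 percentage points lower from compound 1 to compound 2 (within the scatter), concerns the oxygen on the aromatic ring and leaves the carbonyl end of the molecule untouched, so no measured step bears on this change, and the carbonyl end has not been varied among the measured compounds. The expectation for this assay therefore rests on compound 2 alone and carries a wide range. The step expected from this change is a number 7.7 percentage points higher from compound 2 to compound 3 (within the scatter), taken as none beyond the scatter for want of evidence either way. Compound 3 is estimated at 15%, with a range from 4% to 50%.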

Compound 3, a percentage reported as activity, at one concentration (the size of the read-out at that concentration, not a potency): 69%
Estimate against measurement, compound 3: 54 percentage points below; the measured number lies above the stated range.
By their numbers in this assay, from the lowest: compounds 2 and 1 (each within the scatter of the next); then compound 3.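

Among these compounds, the carbonyl end, unchanged between compound 1 and compound 2, is the first part of the molecule seen to vary here, and in this assay it proves sensitive: a number 61.7 percentage points higher from compound 2 to compound 3 (beyond the scatter), whereas the change on the aromatic oxygen stayed within the scatter. This single step changes more than one feature at once, since (3,4-dichlorophenyl)amino carries 1 hydrogen-bond donor and 3-(trifluoromethyl)phenyl carries 0, and the chlorine atoms give way to fluorine atoms on a one-carbon group, so the step belongs to the whole replacement and not to any one of these features. No available evidence accounts for the size of this step.

The compounds shown leave open whether the larger step follows the amino nitrogen on the carbonyl carbon or the substituents on the aromatic ring, a question that (3-(trifluoromethyl)phenyl)amino or a 3,4-dichlorophenyl group directly on the carbonyl carbon would address. Also open, on these data alone, is how other groups on the carbonyl carbon, such as a cyclohexylamino group or a morpholine, would read in this assay.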